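Lengthening the Amine Arm on a Shared Core

The source may report more compounds than this note shows. Statements on the series, on what has been measured and on what is new or still open speak of the compounds shown alone.

Compound 1 `NC[C@@H]1OCCc2ccsc21`: 110%
Compound 2 `c1cc2c(s1)[C@H](CN1CCCC1)OCC2`: 113%

Both values come from a functional assay on CHO-K1 cells for agonist activity at trace amine-associated receptor 1 (Homo sapiens), read by HTRF and cAMP accumulation, with a stated time of 30 min; on this read-out higher numbers stand for larger maximal responses and lower numbers for smaller maximal responses. Compound 2 and compound 1 sit within the scatter of each other, since a number 3 percentage points higher from compound 1 to compound 2 (within the scatter). Compound 3 `NCC[C@@H]1OCCc2ccsc21` differs from compound 2 by aminomethyl in place of pyrrolidin-1-yl on a saturated chain carbon bound to a saturated ring carbon. Going by the values given here, the one measured step, amino exchanged for pyrrolidin-1-yl on a saturated chain carbon bound to a saturated ring carbon, stayed within the scatter; the move to compound 3 largely reverses that exchange while adding one chain carbon. A step of about a number 3 percentage points lower from compound 2 to compound 3 (within the scatter) is therefore expected, not beyond the scatter. Compound 3 is estimated at 110%, ranging from 92% to 126%.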

Compound 3, largest response reached (Emax), in percent of the reference or control that the assay uses: 105%
Estimate against measurement, compound 3: 5 percentage points above; the range from low to high includes it.
By their numbers in this assay, from the lowest: compounds 3, 1 and 2 (each within the scatter of the next).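

In this assay aminomethyl in place of amino on a saturated chain carbon bound to a saturated ring carbon gives a number 5 percentage points lower from compound 1 to compound 3 (within the scatter) and aminomethyl in place of pyrrolidin-1-yl gives a number 8 percentage points lower from compound 2 to compound 3 (within the scatter). At this place, then, all three amine arms shown give maximal responses within the scatter of one another, whether the amine is free or held in a ring. No available evidence explains this.

Still open, as far as these compounds go, is whether a longer chain or a piperidine ring on the arm would also keep the response within that scatter.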